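Halogen swap on the aryl ester of a flavone series

The compounds below may be only part of what the source reports. "The series", "measured", "known", "first", "only" and "open" are said of these compounds alone.

Compound 3 `COC(=O)c1cccc(Cl)c1OC(=O)COc1cc(O)c2c(=O)cc(-c3ccccc3)oc2c1` is tested in an ADME assay on cells (T-cell, Mus musculus, strain BALB/c) for cytotoxicity, read by MTT assay, with a stated time of 48 h (on this read-out higher numbers stand for lower toxicity in this test and lower numbers for higher toxicity in this test), where compound 3 gives 366000 nM. Among the numbers shown it stands highest, with compound 2 `COC(=O)c1cccc(C)c1OC(=O)COc1cc(O)c2c(=O)cc(-c3ccccc3)oc2c1` nearest at 299000 nM, a gap that is a 1.2-fold higher number from compound 2 to compound 3 (0.09 log units; within the scatter). Compound 1 `COC(=O)c1cc(Cl)ccc1OC(=O)COc1cc(O)c2c(=O)cc(-c3ccccc3)oc2c1` reaches only a limit of the assay, > 436000 nM, as recorded in the limit of > 436000 nM in this assay, at which 1 of the 3 values shown sits. Compound 4 `COC(=O)c1cc(F)ccc1OC(=O)COc1cc(O)c2c(=O)cc(-c3ccccc3)oc2c1` differs from compound 3 by a group of 11 heavy atoms (8 carbon, 2 oxygen, 1 fluorine; one six-membered aromatic ring of carbon only) in place of a group of 11 heavy atoms (8 carbon, 2 oxygen, 1 chlorine; one six-membered aromatic ring of carbon only), on an oxygen next to a carbonyl group. The steps that touch this position, an at least 1.1-fold lower number from compound 1 to compound 3 (0.07 log units; that floor lies within the scatter) and an at least 1.4-fold lower number from compound 1 to compound 2 (0.16 log units; that floor lies within the scatter), lie within the scatter, so no step beyond the scatter is expected in this assay. Compound 4 is therefore expected at 380000 nM, between 200000 nM and 700000 nM, an expected step of a 1.0-fold higher number from compound 3 to compound 4 (0.02 log units; within the scatter).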

Compound 4, half-maximal cytotoxic concentration: 389000 nM
Estimate against measurement, compound 4: 1.0-fold (0.01 log units) below, within the range that was stated.
By their numbers in this assay, from the lowest: compounds 2, 3 and 4 (each within the scatter of the next). At a limit, above all of these: compound 1.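

Compared on an oxygen next to a carbonyl group, the group that compound 4 carries gives no step beyond the scatter against the groups of compound 3 and compound 2, with a 1.1-fold higher number from compound 3 to compound 4 (0.03 log units; within the scatter) and a 1.3-fold higher number from compound 2 to compound 4 (0.11 log units; within the scatter). The fluoro for chloro change thus joins the earlier changes here in showing no readable effect. Fluoro in place of chloro on an aromatic carbon gives an at least 1.1-fold lower number from compound 1 to compound 4 (0.04 log units; that floor lies within the scatter). That step is only a floor and cannot be read further, since compound 1 stands at a limit: the limit of > 436000 nM in this assay, at which 1 of the 4 values shown sits.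

The compounds shown leave open whether a carboxylic acid in place of the methoxycarbonyl, or an amine in place of the halogen, would move the number beyond the scatter.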